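The source may report more compounds than this note shows. Statements on the series, on what has been measured and on what is new or still open speak of the compounds shown alone.

Three thioureas built on one shared core have been tested in an ADME assay on Ava5 cells (Homo sapiens) for cytotoxicity; a lower number here means that less compound is tolerated, a higher number that more compound is tolerated. Compound 1, `NC(=S)Nc1cccc(OCc2ccccc2)c1`, gives > 50000 nM in this assay, which is a limit of the assay rather than a number. Compound 2, `NC(=S)Nc1cccc(NCCCCCc2ccccc2)c1`, likewise gives > 50000 nM in this assay, again a limit and not a number. Among the compounds with values here, compound 3, `NC(=S)Nc1cccc(OCCCCCOc2ccc(F)cc2)c1`, is the one member of the set for which this assay returns an actual number: compound 3 gives 5000 nM. Compound 3 therefore stands apart on the numbers shown, because the limit of > 50000 nM in this assay, at which 2 of the 3 values shown sit, holds the other two values, and nothing more can be said about the distance between compound 3 and those two than that one is a number and the others are limits.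

Compound 4, `NC(=S)Nc1cccc(OCCCCCOc2ccc(-c3cccs3)cc2)c1`, differs from compound 3 in a single place: thiophen-2-yl in place of fluoro on an aromatic carbon. The thiophen-2-yl ring enters on the six-membered aromatic ring of carbon only, where the fluoro leaves. Within the data shown here, no measured pair in this set shares such a change, so the size of the step cannot be read from other compounds. The expected step in this assay is a 1.3-fold lower number from compound 3 to compound 4 (0.10 log units; within the scatter), small and, if anything, toward a lower tolerated concentration. Compound 4 is accordingly estimated at 4000 nM in this assay, within a range from 1500 nM to 15000 nM.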

Compound 4, half-maximal cytotoxic concentration: > 50000 nM
Compound 4: a limit, no number; the forecaster's own chance of this, stated with the estimate: 15%; middle value at least 12-fold (1.09 log units) away from the limit.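

Replacing fluoro with thiophen-2-yl on this aromatic carbon, para to a large group, gives an at least 10-fold higher number from compound 3 to compound 4 (1.00 log units; beyond the scatter) in this assay. Within the data shown here, the earlier compounds included no pair that differed in one place, so this is the first direct sign that the group at this position can change how much compound the cells tolerate, and that a single substitution here can be enough to move the result beyond the usual scatter. The result for compound 4 is a limit and not a number, so the step sets only a minimum size for the change, and most of the set now sits at the same limit: the limit of > 50000 nM in this assay, at which 3 of the 4 values shown sit.

The compounds shown leave open whether the number for compound 3 is particular to fluoro, or whether a hydrogen, a chlorine, a methoxy group or a phenyl ring on this carbon would give a number or a limit. They also leave open what a thiophen-3-yl ring, an amine, a carboxylic acid or a longer chain would do, and a single step cannot show why the change has this effect.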